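A few compounds are considered here, and "the series" means these few. Any claim that something is new, unique, unknown or untested is made for them only; others in the source may bear on it.

Working notes on the series. The core is that of compound 1 `COc1cc(-c2nnc3n2NC(c2ccco2)C(C(=O)c2ccc(F)cc2)S3)cc(OC)c1OC`; compound 2 `COc1cc(-c2nnc3n2NC(c2cccs2)C(C(=O)c2ccc(C)cc2)S3)cc(OC)c1OC` and compound 3 `COc1cc(-c2nnc3n2NC(c2cccs2)C(C(=O)c2ccccc2)S3)cc(OC)c1OC` share it and differ from compound 1 at two places, and compound 4 `COc1cc(-c2nnc3n2NC(c2cccs2)C(C(=O)c2ccc(F)cc2)S3)cc(OC)c1OC` has not yet been measured. In a functional assay on HepG2 cells (Homo sapiens) for cytotoxicity, read by MTT assay, with a stated time of 48 h (on this read-out higher numbers stand for weaker inhibition and lower numbers for stronger inhibition), compound 1 gives only a limit of the assay, > 100000 nM. Compound 2 gives 3700 nM in this assay. Compound 3 likewise reaches only a limit, > 100000 nM. Going by the values given here, the single measured step, an at least 27-fold higher number from compound 2 to compound 3 (1.43 log units; beyond the scatter), leaves compound 3 at the end of the range, where the limit of the limit of > 100000 nM in this assay, at which 2 of the 3 values shown sit, puts a floor under what can be said about it.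

The change to compound 4 is fluoro in place of hydrogen on an aromatic carbon. Among the compounds with values here, no measured step covers this change on its own; the only compound carrying the fluoro group is compound 1, and its value is a limit, so it shows nothing that would push the number back down. Given where compound 3 stands, compound 4 is expected to remain at the limit, with an estimate of 100000 nM (range 30000 nM to 300000 nM). The step of a number no higher from compound 3 to compound 4 (the limit leaves the size open) is therefore expected to be none beyond the scatter.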

Compound 4, half-maximal inhibitory concentration: 54200 nM
Compound 4: the middle estimate sits 1.8-fold (0.27 log units) above what was measured; measured number inside the range.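

In this assay, fluoro in place of methyl on the same aromatic carbon gives a 15-fold higher number from compound 2 to compound 4 (1.17 log units; beyond the scatter), so fluoro does not reproduce the result seen with methyl at this position, and among compound 2, compound 3 and compound 4 methyl stands apart. Against hydrogen the result is an at least 1.8-fold lower number from compound 3 to compound 4 (0.26 log units; that floor lies within the scatter), and with furan-2-yl replaced by thiophen-2-yl it is an at least 1.8-fold lower number from compound 1 to compound 4 (0.26 log units; that floor lies within the scatter); both steps start from a limit of the assay and both floors lie within the scatter, so neither change can be given a size, and the series still rests heavily on such limits: the limit of > 100000 nM in this assay, at which 2 of the 4 values shown sit. What is new is that a fluoro group on this ring, para to a large group, now has a measured number alongside thiophen-2-yl, which gives the methyl compound a second measured point of comparison at this position.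

Whether the methyl result is specific to methyl stays open, as an ethyl, a methoxy or a chloro group at the same place is not among the compounds shown. Whether methyl carries over with furan-2-yl in place of thiophen-2-yl also remains unanswered.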